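Working notes on compounds 1 to 4

A few compounds are considered here, and "the series" means these few. Any claim that something is new, unique, unknown or untested is made for them only; others in the source may bear on it.

Compound 1, `Nc1[nH]nc2nnc(-c3ccc([N+](=O)[O-])cc3)c(-c3ccc([N+](=O)[O-])cc3)c12`: in a functional assay on HT-29 cells (Homo sapiens) for cytotoxicity (a higher number here means a weaker inhibitor, a lower number a stronger inhibitor), compound 1 gives > 100000 nM, a limit of the assay.
Compound 2, `Nc1nn(COCCO)c2nnc(-c3ccccc3)c(-c3ccccc3)c12`: in this assay compound 2 gives > 100000 nM, a limit of the assay.
Compound 3, `Nc1nn(CCOCCO)c2nnc(-c3ccccc3)c(-c3ccccc3)c12`: in this assay compound 3 gives > 100000 nM, a limit of the assay.

Compound 3 therefore stands only at a limit in this assay, with no number of its own; the other two values sit at the same limit, (the limit of > 100000 nM in this assay, at which 3 of the 3 values shown sit). For the measured compounds named here, the one measured step at the saturated chain carbon bound to the aromatic nitrogen, a step that the two limits leave unreadable from compound 2 to compound 3, is left unreadable by the two limits, so it gives no size in either direction.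

Compound 4, `Nc1nn(Cc2ccccc2)c2nnc(-c3ccccc3)c(-c3ccccc3)c12`, differs from compound 3 in one place: phenyl in place of (2-hydroxyethoxy)methyl on a saturated chain carbon bound to an aromatic nitrogen. No measured step brings a phenyl onto this carbon, so nothing measured bears on it beyond the unreadable step from the two limits, and no step beyond the scatter can be read from the numbers shown.

Compound 4 is accordingly expected to give about 100000 nM in this assay, in the range 30000 nM to 300000 nM, most probably reported again as a limit. The step this estimate means, a number no higher from compound 3 to compound 4 (the limit leaves the size open), is expected to be no readable change.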

Compound 4, half-maximal inhibitory concentration: > 100000 nM
Compound 4 was reported as a limit (the forecaster's own chance of this, stated with the estimate: 80%); the middle value lies on the limit itself.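

No step to compound 4 can be read from compound 2 or compound 3, as every value in this assay is a limit: the limit of > 100000 nM in this assay, at which 4 of the 4 values shown sit.

The compounds shown leave open how large these steps are, and which change to the shared core would give a number rather than a limit.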